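Swapping Methyl for Chloro on the Thiophene Ring

This account rests on a few compounds, and the source may have more. Where it says the series, first, only, none or still open, it means among the compounds named here.

Compound 1 `Cc1ccc(C2=NN(c3nc(-c4ccc(F)cc4)cs3)C(c3ccc(F)cc3)C2)s1` stands second highest of the three numbers in a functional assay on A549 cells (Homo sapiens) for antiproliferative activity, read by XTT assay, with a stated time of 24 h (on this read-out lower numbers stand for stronger inhibition and higher numbers for weaker inhibition), where compound 1 gives 125 ug/mL. Compound 3 `COc1ccc(-c2csc(N3N=C(c4ccc(C)s4)CC3c3ccc(F)cc3)n2)cc1` gives 184 ug/mL. The step of a 1.5-fold higher number from compound 1 to compound 3 (0.17 log units; within the scatter) stays within the scatter. Compound 2 `Cc1ccc(C2=NN(c3nc(-c4ccc([N+](=O)[O-])cc4)cs3)C(c3ccc(F)cc3)C2)s1` gives 16.7 ug/mL. The step of a 7.5-fold lower number from compound 1 to compound 2 (0.87 log units; beyond the scatter) is a modest one. Compound 4 `Fc1ccc(-c2csc(N3N=C(c4ccc(Cl)s4)CC3c3ccc(F)cc3)n2)cc1` differs from compound 1 by chloro in place of methyl on an aromatic carbon. For the measured compounds named here, none of the measured steps touches this group; each of them changes a different group on another ring of the shared core, so they give no direct guide. The expected step of no change at the digits printed from compound 1 to compound 4 (within the scatter) is therefore taken to lie within the scatter. Compound 4 is estimated at 125 ug/mL, with a range from 45 ug/mL to 350 ug/mL.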

Compound 4, half-maximal inhibitory concentration: > 500 ug/mL
Compound 4: no number, only a limit; the forecaster's own chance of this, stated with the estimate: 10%; at least 4.0-fold (0.60 log units) between middle value and limit.
By their numbers in this assay, from the lowest: compound 2; then compounds 1 and 3 (each within the scatter of the next). At a limit, above all of these: compound 4.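

For the compounds shown here, until now, only the group on another ring of the shared core had changed, so this is the first sign that the group on the thiophene also matters: moving from 5-methylthiophen-2-yl to 5-chlorothiophen-2-yl gives an at least 4.0-fold higher number from compound 1 to compound 4 (0.60 log units; beyond the scatter). On this read-out, that means weaker inhibition. Compound 4 has a limit, not a number: the limit of > 500 ug/mL in this assay, at which 1 of the 4 values shown sits.

Whether any group other than methyl would weaken inhibition here remains open, as the compounds shown include no ethyl group or amine at this position. Also open, as far as these compounds go, is whether chloro would have the same effect alongside the nitro group of compound 2.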